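The source may hold more compounds than are shown below. What is called first, only, known or untested is meant among the compounds shown, and "the series" means these compounds.

Of the compounds shown here, three built on one shared core have been tested in a functional assay on PC-3 cells (Homo sapiens) for inhibition, read by sulforhodamine B assay, with a stated time of 72 h; a higher number here means a weaker inhibitor, a lower number a stronger inhibitor. Compound 1 `Nc1sc(-c2ccc(Cl)cc2)c(-c2ccc(Cl)cc2)c1C(=O)N1CCCC1` gives 6220 nM. Compound 2 `CC(C)(C)NC(=O)c1c(N)sc(-c2ccc(Cl)cc2)c1-c1ccc(Cl)cc1` gives 15100 nM in this assay. Compound 3 `Nc1sc(-c2ccc(Cl)cc2)c(-c2ccc(Cl)cc2)c1C(=O)NC1CCCCC1` gives 7300 nM in this assay, the second highest of the three numbers: compound 3 lies within the scatter of compound 1, and a 2.1-fold lower number from compound 2 to compound 3 (0.32 log units; beyond the scatter). Compound 4 `Nc1sc(-c2ccc(Cl)cc2)c(-c2ccc(Cl)cc2)c1C(=O)N1CCNCC1` is not yet measured. It differs from compound 3 in one place: piperazin-1-yl in place of cyclohexylamino on a carbonyl carbon. The most relevant measured step is a 1.2-fold higher number from compound 1 to compound 3 (0.07 log units; within the scatter), which likewise exchanges cyclohexylamino for a group bound through a ring nitrogen, pyrrolidin-1-yl, on the carbonyl carbon. The other two, a 2.4-fold higher number from compound 1 to compound 2 (0.39 log units; beyond the scatter) and a 2.1-fold lower number from compound 2 to compound 3 (0.32 log units; beyond the scatter), show that changes at this carbonyl carbon have moved the number only modestly. Among the measured compounds shown here, no measured step introduces a second nitrogen at this place, so the added hydrogen-bond acceptor of piperazin-1-yl is untested. A step of about a 1.1-fold higher number from compound 3 to compound 4 (0.04 log units; within the scatter) is therefore expected, most likely within the scatter. Compound 4 is estimated at 8000 nM, with a range from 3000 nM to 25000 nM.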

Compound 4, half-maximal inhibitory concentration: 2710 nM
Beside the measured number, compound 4's estimate is 3.0-fold (0.47 log units) above it; the measured number lies below the stated range.
By their numbers in this assay, from the lowest: compound 4; then compounds 1 and 3 (each within the scatter of the next); then compound 2.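

In this assay piperazin-1-yl on a carbonyl carbon brings a 2.7-fold lower number from compound 3 to compound 4 (0.43 log units; beyond the scatter) and a 2.3-fold lower number from compound 1 to compound 4 (0.36 log units; beyond the scatter) and also a 5.6-fold lower number from compound 2 to compound 4 (0.75 log units; beyond the scatter) so compound 4 is the strongest inhibitor of the four. This place is therefore more responsive than compounds 1 and 3 alone suggested: their two different groups lie within the scatter of each other, yet a third group stands clearly apart from both. Pyrrolidin-1-yl already binds through a ring nitrogen and cyclohexylamino already brings a six-membered ring, so what is new in piperazin-1-yl is the second ring nitrogen.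

On these data alone, whether that second nitrogen matters remains open, and morpholin-4-yl, with an oxygen in its place, or 4-methylpiperazin-1-yl would test it. Nothing available here explains the lower number.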